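Ortho-Chloro on the Benzyl Arm of Compound 1

The source may report more compounds than this note shows. Statements on the series, on what has been measured and on what is new or still open speak of the compounds shown alone.

Compound 1 `N=c1c(C(N)=O)cc(Cl)cn1Cc1ccccc1` gives the lowest number of the three measured compounds in an assay on CHO-K1 cells for displacement of a labelled ligand from Alpha-1D adrenergic receptor (Homo sapiens), read by scintillation counting, with a stated time of 60 min (on this read-out higher numbers stand for weaker inhibition and lower numbers for stronger inhibition), at 30 nM. Compound 2 `N=c1c(C(N)=O)cc(Cl)cn1Cc1ccco1` gives 160 nM in this assay, and compound 3 `N=c1c(C(N)=O)cc(Cl)cn1Cc1ccccn1` gives 420 nM. Both measured steps away from compound 1 replace the whole phenyl: a 5.3-fold higher number from compound 1 to compound 2 (0.73 log units; beyond the scatter), and a 14-fold higher number from compound 1 to compound 3 (1.15 log units; beyond the scatter); between the two heteroaryls, a 2.6-fold higher number from compound 2 to compound 3 (0.42 log units; beyond the scatter).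

Compound 4 `N=c1c(C(N)=O)cc(Cl)cn1Cc1ccccc1Cl` keeps the phenyl of compound 1 and differs only by chloro in place of hydrogen on an aromatic carbon, the place being on an aromatic carbon of a six-membered aromatic ring of carbon only, ortho to a large group. Among the measured compounds shown here, no measured step adds a substituent to the phenyl; the steps from compound 1 to compounds 2 and 3 tell only that the phenyl itself is favourable in this assay. Compound 4 is therefore expected to stay close to compound 1, with a step of no change at the digits printed from compound 1 to compound 4 (within the scatter) that need not pass beyond the scatter. The estimate for compound 4 in this assay is 30 nM, within 10 nM to 100 nM.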

Compound 4, inhibition constant: 39 nM
Compound 4: middle estimate off by 1.3-fold (0.11 log units), on the low side, and the stated range covers the measured number.
By their numbers in this assay, from the lowest: compounds 1 and 4 (each within the scatter of the next); then compound 2; then compound 3.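

In this assay, among the compounds shown here, the step of a 1.3-fold higher number from compound 1 to compound 4 (0.11 log units; within the scatter) is the first measured change that keeps the phenyl, whereas the earlier steps replaced the whole ring. It shows that chloro can stand in place of hydrogen on this aromatic carbon, ortho to a large group, with no change beyond the scatter, so the phenyl of compound 1 need not remain unsubstituted at this place. No supporting evidence bears on why this step is so small.

The compounds shown leave open whether a larger or different group at this place, such as methoxy, an amine or a carboxylic acid, would be tolerated as well as chloro. They also do not show how chloro behaves on the other aromatic carbons of the phenyl, or whether a longer chain to the phenyl would keep the number of compound 1.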